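Three aryl esters on a shared core, and a fourth to come

This account rests on a few compounds, and the source may have more. Where it says the series, first, only, none or still open, it means among the compounds named here.

Compound 1 `CC(C)(C)c1ccc(OC(=O)c2cn(-c3ccccc3)nc2-c2cccnc2)cc1`: > 100000 nM
Compound 2 `CCc1ccc(OC(=O)c2cn(-c3ccccc3)nc2-c2ccncc2)cc1`: "nd(insoluble)" (no result reported)
Compound 3 `CC(C)c1cccc(OC(=O)c2cn(-c3ccccc3)nc2-c2ccncc2)c1`: "nd(insoluble)" (no result reported)

In a functional assay on HL-60 cells (Homo sapiens) for cytotoxicity, read by MTT assay, with a stated time of 48 h (on this read-out higher numbers stand for weaker inhibition and lower numbers for stronger inhibition), compound 1 is reported only as a limit of the assay, > 100000 nM. For compound 2 the entry in this assay is "nd(insoluble)" (no result reported), so no number stands against it. Compound 3 fares the same way: in this assay it is recorded as "nd(insoluble)" (no result reported), and there is no single number for it. Of the three values shown, one is a limit and two carry no result at all, so compound 3 cannot be placed on a scale among its neighbours; all that can be said is that none of the three gave a measurable concentration.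

Compound 4 `CC(C)(C)c1ccc(OC(=O)c2cn(-c3ccccc3)nc2-c2ccncc2)cc1` differs from compound 3 by one change: 4-(tert-butyl)phenyl in place of 3-isopropylphenyl on an oxygen next to a carbonyl group. Within the data shown here, the 4-(tert-butyl)phenyl group that enters is the one carried by compound 1, which sits at the limit (the limit of > 100000 nM in this assay, at which 1 of the 3 values shown sits).

Among the measured compounds shown here, no measured step exists that would set a size or direction for this change. Compound 1 gives > 100000 nM in this assay, which is a limit of the assay. Compound 3 gives "nd(insoluble)" (no result reported), no result at all. On that footing the expectation for compound 4 is that this assay again reports either no result or a limit rather than a number. Compound 4 is therefore estimated at 100000 nM, within a range of 30000 nM to 300000 nM.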

Compound 4, half-maximal inhibitory concentration: 18700 nM
For compound 4 the middle estimate is 5.3-fold (0.73 log units) above the measured one; measured number below the stated range.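

With the 4-(tert-butyl)phenyl group held fixed on the ester oxygen, the result shows that the aromatic carbon of the shared core bearing the pyridine ring is a place where a single change can be read. In this assay, among these compounds, pyridin-4-yl in place of pyridin-3-yl gives an at least 5.3-fold lower number from compound 1 to compound 4 (0.72 log units; beyond the scatter), and compound 4 is the only one of the four compounds with a measured concentration. The size of this step is open-ended, as compound 1 stands at a limit and not at a number: the limit of > 100000 nM in this assay, at which 1 of the 4 values shown sits.

The compounds shown leave open whether pyridin-2-yl at the same aromatic carbon would lower the number further, and whether the effect of pyridin-4-yl would persist with an amine or a carboxylic acid on the phenyl ring of the ester. From the compounds shown here alone, the exchange of 3-isopropylphenyl for 4-(tert-butyl)phenyl also cannot be read, since compound 3 has no result in this assay, and so the contribution of the ester group to the number for compound 4 remains unknown.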